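Hydroxy to hydroxymethyl on the ring-bound chain: expected inhibition

The source may hold more compounds than are shown below. What is called first, only, known or untested is meant among the compounds shown, and "the series" means these compounds.

Of the compounds shown here, two have so far been measured in a functional assay on MCF7 cells (Homo sapiens) for inhibition, read by MTT assay, with a stated time of 72 h, tested at 30 uM; on this read-out higher numbers stand for more inhibition of growth at the one concentration tested and lower numbers for less inhibition of growth. Compound 1, `C=CCc1ccc(OCc2cn(-c3ccccc3CO)nn2)c(O)c1`, gives 34.5% in this assay. Compound 2, `C=CCc1cc(O)c(O)c(CN2CCC(CO)CC2)c1`, gives 26.2% in this assay. The gap between these two numbers lies within the usual scatter of repeated measurements, so on this read-out compound 2 stands alongside compound 1 and the two cannot be told apart. For the measured compounds named here, no step between measured compounds that differ in one place is available, so the measured pair gives no calibration for how a single small change moves the read-out.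

The unmeasured compound 3, `C=CCc1cc(O)c(O)c(CN2CCC(CCO)CC2)c1`, differs from compound 2 in one place: hydroxymethyl in place of hydroxy on a saturated chain carbon bound to a saturated ring carbon. The rest of the structure, shared with compound 2, is unchanged. Going by the values given here, for a change of this size, with no measured step to set its scale, the step from compound 2 to compound 3 is expected to be a number 0.8 percentage points higher from compound 2 to compound 3 (within the scatter), which is no step beyond the scatter. Compound 3 is accordingly expected to give 27% in this assay, with a range from 14% to 40%.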

Compound 3, percent growth inhibition at one concentration: 21.4%
For compound 3 the middle estimate is 5.6 percentage points above the measured one, within the range that was stated.
By their numbers in this assay, from the lowest: compounds 3, 2 and 1 (each within the scatter of the next, the first and the last beyond it).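

The step at this place now has a first calibration: with hydroxymethyl in place of hydroxy on a saturated chain carbon bound to a saturated ring carbon, this assay gives a number 4.8 percentage points lower from compound 2 to compound 3 (within the scatter). The shared core and the hydrogen-bond donor and acceptor counts of the changing group stay as they were, while the group gains one carbon, and this single change does not separate the two compounds on this read-out, so a chain of either length at this place remains compatible with the inhibition seen so far. No available evidence bears on this step.

The compounds shown leave open whether a longer chain, an amine or a carboxylic acid at this place would give a step beyond the scatter, since one step within the scatter sets no limit on what a larger change would do. They also leave open whether the same change, hydroxymethyl to 2-hydroxyethyl, would read alike on a different core, as this single pair speaks only for the core shared by compound 2 and compound 3.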